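The source may hold more compounds than are shown below. What is called first, only, known or untested is meant among the compounds shown, and "the series" means these compounds.

Compound 1 `COc1ccc2cc([C@H](C)c3nnc(SCc4ccc(F)cc4)n3-c3ccc(F)cc3)ccc2c1` gives 60200 nM in a functional assay on DU-145 cells (Homo sapiens) for cytotoxicity, read by MTT assay; a higher number here means a weaker inhibitor, a lower number a stronger inhibitor.
Compound 2 `COc1ccc2cc([C@H](C)c3nnc(SCc4ccc(C)cc4)n3-c3ccc(Cl)cc3)ccc2c1` gives 18800 nM in this assay.
Compound 3 `COc1ccc2cc([C@H](C)c3nnc(SCc4ccc(C)cc4)n3-c3ccc(F)cc3)ccc2c1` gives 44300 nM in this assay.

Compound 2 has the lowest number of the three: compound 3 stands a 2.4-fold higher number from compound 2 to compound 3 (0.37 log units; beyond the scatter) away, and the number for compound 1 is higher still. Compound 4 `COc1ccc2cc([C@H](C)c3nnc(SCc4ccc(Cl)cc4)n3-c3ccc(Cl)cc3)ccc2c1` is derived from compound 2 by a single change: chloro in place of methyl on an aromatic carbon. Among the measured compounds shown here, no measured step exchanges chloro for methyl at this place. The closest comparison is the step from compound 1 to compound 3, a 1.4-fold lower number from compound 1 to compound 3 (0.13 log units; within the scatter), where methyl in place of fluoro on the same ring moved the number only within the scatter. The step from compound 2 to compound 3, a 2.4-fold higher number from compound 2 to compound 3 (0.37 log units; beyond the scatter), concerns a different ring and shows chloro there giving a lower number than fluoro. Since exchanges of small groups on the benzyl ring have so far done little, a step of a 1.3-fold lower number from compound 2 to compound 4 (0.10 log units; within the scatter) is expected, within the scatter. Compound 4 is therefore estimated at 15000 nM, in the range 7000 nM to 35000 nM.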

Compound 4, half-maximal inhibitory concentration: 109000 nM
The estimate for compound 4 lay 7.3-fold (0.86 log units) below the measured number; measured number outside the range, above it.
By their numbers in this assay, from the lowest: compound 2; then compounds 3, 1 and 4 (each within the scatter of the next, the first and the last beyond it).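

The group on the benzyl ring matters after all: going from 4-methylbenzyl to 4-chlorobenzyl gives a clear loss of cytotoxic strength (a 5.8-fold higher number from compound 2 to compound 4 (0.76 log units; beyond the scatter)), unlike the earlier exchange of fluoro for methyl at this place (a 1.4-fold lower number from compound 1 to compound 3 (0.13 log units; within the scatter)), which stayed within the scatter. Chloro is also not helpful wherever it is placed, since on the other ring it goes with the lower number (a 2.4-fold higher number from compound 2 to compound 3 (0.37 log units; beyond the scatter)), whereas here it goes with the higher one. Nothing available explains why this exchange raises the number.

The compounds shown leave open whether 4-chlorobenzyl would have the same effect with fluoro rather than chloro on the other ring. They also leave open how an amine, a nitrile or a carboxylic acid would behave at this place.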